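The compounds below may be only part of what the source reports. "The series", "measured", "known", "first", "only" and "open" are said of these compounds alone.

Compound 1, with structure `Cc1ccc(N)cc1S(=O)(=O)N(C)/N=C/c1cnn2ccc(C#N)cc12`, is recorded in a functional assay on NZB5 cells (Homo sapiens) for inhibition, read by thymidine incorporation, with a stated time of 5 days (a higher number here means a weaker inhibitor, a lower number a stronger inhibitor), as "not determined" (no result reported), so it cannot be placed by a number of its own. Two companions give the scale. Compound 2, with structure `CN(C)c1ccc([N+](=O)[O-])cc1S(=O)(=O)N(C)/N=C/c1cnn2ccc(C#N)cc12`, gives 40 nM in this assay. Compound 3, with structure `Cc1ccc([N+](=O)[O-])cc1C(=O)N(C)/N=C/c1cnn2ccc(C#N)cc12`, reaches only a limit in this assay, > 20000 nM, a value that is a boundary of the measurement and not a number, as noted in the limit of > 20000 nM in this assay, at which 1 of the 3 values shown sits. For the measured compounds named here, the pair thus shows that a sulfonamide-bearing member can be potent while the amide-bearing member is not, though with only two values no pattern beyond them is claimed.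

The step to compound 4, with structure `Cc1ccc(C)c(S(=O)(=O)N(C)/N=C/c2cnn3ccc(C#N)cc23)c1`, changes compound 1 by methyl in place of amino on an aromatic carbon. Going by the values given here, since compound 1 has no value, no measured step exists to compare against, and the expectation rests on compound 2 alone, which shares the sulfonamide linkage. Compound 4 is therefore expected to give 300 nM in this assay, within a range of 30 nM to 5000 nM.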

Compound 4, half-maximal inhibitory concentration: 2100 nM
Beside the measured number, compound 4's estimate is 7.0-fold (0.85 log units) below it; low and high end bracket the measured number.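

For the compounds shown here, with compound 1 recorded as "not determined" (no result reported), the change from amino to methyl cannot be read as a step to compound 4, and no new step follows. The compounds shown leave open how amino and methyl compare in this assay on an otherwise unchanged compound.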